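This account rests on a few compounds, and the source may have more. Where it says the series, first, only, none or still open, it means among the compounds named here.

Compound 3 `COc1ncc(-c2ccc3nc(NC(=O)NC4CC4)sc3c2)cc1NS(=O)(=O)c1ccc(F)cc1` gives 470 nM in a functional assay on HCT-116 cells (Homo sapiens) for antiproliferative activity, read by MTT assay, with a stated time of 72 h (on this read-out lower numbers stand for stronger inhibition and higher numbers for weaker inhibition), the highest of the three numbers shown, though compound 1 `COc1ncc(-c2ccc3nc(NC(=O)NCCN4CCCC4)sc3c2)cc1NS(=O)(=O)c1ccc(F)cc1` at 310 nM and compound 2 `COc1ncc(-c2ccc3nc(NC(=O)NCCN(C)C)sc3c2)cc1NS(=O)(=O)c1ccc(F)cc1` at 240 nM both lie within the scatter of it. The steps are small: a 1.5-fold higher number from compound 1 to compound 3 (0.18 log units; within the scatter) and a 2.0-fold higher number from compound 2 to compound 3 (0.29 log units; within the scatter). Compound 4 `CNC(=O)Nc1nc2ccc(-c3cnc(OC)c(NS(=O)(=O)c4ccc(F)cc4)c3)cc2s1` differs from compound 3 by methyl in place of cyclopropyl on an amide-type nitrogen. For the measured compounds named here, the steps that bear on this change are those that alter the substituent on the same amide-type nitrogen, from 2-(pyrrolidin-1-yl)ethyl or 2-(dimethylamino)ethyl to cyclopropyl, and neither moved the number beyond the scatter; a 1.3-fold lower number from compound 1 to compound 2 (0.11 log units; within the scatter) likewise stayed within it. Compound 4 is therefore expected to show no shift beyond the scatter, a 1.1-fold higher number from compound 3 to compound 4 (0.03 log units; within the scatter). Compound 4 is estimated at 500 nM, within 250 nM to 1000 nM.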

Compound 4, half-maximal inhibitory concentration: 870 nM
Compound 4: middle estimate off by 1.7-fold (0.24 log units), on the low side; the range from low to high includes it.
By their numbers in this assay, from the lowest: compounds 2, 1, 3 and 4 (each within the scatter of the next, the first and the last beyond it).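

In this assay, methyl in place of cyclopropyl on this amide-type nitrogen gives a 1.9-fold higher number from compound 3 to compound 4 (0.27 log units; within the scatter), so this change alone stays unresolved. Methyl does, however, separate from both amine-bearing chains, which cyclopropyl did not: a 3.6-fold higher number from compound 2 to compound 4 (0.56 log units; beyond the scatter) and a 2.8-fold higher number from compound 1 to compound 4 (0.45 log units; beyond the scatter). Nothing measured here accounts for this separation. The compounds shown leave open how an ethyl or 2-hydroxyethyl group on this nitrogen would read. They also leave open whether the gap depends on the terminal amine or on chain length alone, which a 2-methoxyethyl group could test.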